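Swapping the aryl group on a shared core

The source may hold more compounds than are shown below. What is called first, only, known or untested is meant among the compounds shown, and "the series" means these compounds.

Compound 2 `O=C(O)CCc1ccc(OCc2nc(-c3ccc(F)cc3)no2)cc1`: 680 nM
Compound 1 `O=C(O)CCc1ccc(OCc2coc(-c3ccccc3)n2)cc1`: 700 nM

In a functional assay on CHO cells for agonist activity at Free fatty acid receptor 1 (Homo sapiens), read by FLIPR and calcium flux, in the presence of a further agent that is not named here (on this read-out lower numbers stand for an effect already at smaller amounts and higher numbers for an effect only at larger amounts of compound), compound 2 gives 680 nM, and compound 1 gives 700 nM; the two values sit within the usual scatter of each other, so neither can be called the more potent.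

Compound 3 `O=C(O)CCc1ccc(OCc2nc(-c3cccc(Br)c3)no2)cc1` differs from compound 2 in one place: 3-bromophenyl in place of 4-fluorophenyl on an aromatic carbon. Among the compounds with values here, no measured pair shows the effect of such an exchange, so the direction of the change is open. The expected step is a 1.1-fold lower number from compound 2 to compound 3 (0.05 log units; within the scatter), with no change beyond the scatter. For compound 3 the expected value in this assay is 600 nM, between 200 nM and 2000 nM.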

Compound 3, half-maximal effective concentration: 1260 nM
Compound 3: middle estimate off by 2.1-fold (0.32 log units), on the low side; the measured number falls inside the stated range.
By their numbers in this assay, from the lowest: compounds 2, 1 and 3 (each within the scatter of the next).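

In this assay, 3-bromophenyl in place of 4-fluorophenyl on this aromatic carbon gives a 1.9-fold higher number from compound 2 to compound 3 (0.27 log units; within the scatter). This is the first exchange at this position shown here, and it does not separate the two aryl groups. Nothing measured here bears on the reason for this result. The two groups differ both in the halogen and in where it sits on the phenyl ring, so the effect of each remains unresolved. Also open, going by these compounds, is how 4-bromophenyl, unsubstituted phenyl or an aminophenyl group would read out on the shared core.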